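Methoxy to Methyl: Expecting the Cytotoxicity of Compound 3

A few compounds are considered here, and "the series" means these few. Any claim that something is new, unique, unknown or untested is made for them only; others in the source may bear on it.

Compound 1 `C=C1C(=O)O[C@H](c2ccccc2)[C@H]1c1ccccc1` gives 1%.
Compound 2 `C=C1C(=O)O[C@H](c2ccc(OC)cc2)[C@H]1c1ccccc1` gives 0%.

Both compounds were tested in a functional assay on MIA PaCa-2 cells (Homo sapiens) for cytotoxicity, read by MTT assay, with a stated time of 72 h, tested at 10 uM; on this read-out higher numbers stand for a weaker effect at the one concentration tested and lower numbers for a stronger effect. Among the measured compounds shown here, compound 2 stands alongside compound 1 on these numbers; the only measured step, a number 1 percentage points lower from compound 1 to compound 2 (within the scatter), is within the scatter, so the two cannot be told apart, and both read close to nothing. Compound 3 `C=C1C(=O)O[C@H](c2ccc(C)cc2)[C@H]1c1ccccc1` differs from compound 2 in one place: methyl in place of methoxy on an aromatic carbon. For the measured compounds named here, the one measured step bears on this only loosely, since it concerns a different pair of groups, and it was too small to show any effect. With compound 1 and compound 2 both near zero, the expected step of a number 1 percentage points higher from compound 2 to compound 3 (within the scatter) is none beyond the scatter. Compound 3 is therefore estimated at 1%, with a range from -8% to 11%.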

Compound 3, a percentage reported as activity, at one concentration (the size of the read-out at that concentration, not a potency): 2%
Estimate against measurement, compound 3: 1 percentage points below; measured number inside the range.
By their numbers in this assay, from the lowest: compounds 2, 1 and 3 (each within the scatter of the next).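

In this assay, replacing methoxy with methyl gives a number 2 percentage points higher from compound 2 to compound 3 (within the scatter), and placing methyl on the unsubstituted aromatic carbon gives a number 1 percentage points higher from compound 1 to compound 3 (within the scatter). This position, para to a large group, has now carried hydrogen, methoxy and methyl with no difference beyond the scatter, and removing the hydrogen-bond acceptor of methoxy does not move the read-out beyond it either. No measurement here explains this tolerance of the three groups.

On these data alone, it remains open whether an amine or a carboxylic acid at this place would raise the number well clear of the scatter. All three compounds read near zero at a single concentration, so any difference among them in the strength of their effect at lower concentrations could remain hidden.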